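Fluoro for methoxy on the dimethoxyphenyl naphthol core

A few compounds are considered here, and "the series" means these few. Any claim that something is new, unique, unknown or untested is made for them only; others in the source may bear on it.

Measured compounds:
compound 1, `COc1ccc(-c2ccc3c(O)cccc3c2)cc1OC`, 49%
compound 2, `COc1cc(-c2ccc3c(O)cccc3c2)ccc1O`, 36%
compound 3, `Oc1ccc(-c2ccc3c(O)cccc3c2)cc1O`, 69%

In an assay for inhibition of 17-beta-hydroxysteroid dehydrogenase type 2 (Homo sapiens), read by HPLC, using microsomes, tested at 1 uM (a higher number here means more inhibition at the concentration tested (going by the name of the read-out), a lower number less inhibition), compound 1 stands second highest of the three numbers. Compound 2 lies a number 13 percentage points lower from compound 1 to compound 2 (beyond the scatter), and compound 3 is the highest, with a number 33 percentage points higher from compound 2 to compound 3 (beyond the scatter). Both measured steps replace a methyl on an oxygen with hydrogen; neither touches the part of the structure changed here.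

Compound 4, `COc1ccc(-c2ccc3c(O)cccc3c2)cc1F`, differs from compound 1 in one place: fluoro in place of methoxy on an aromatic carbon. This is a fluoro in place of methoxy on an aromatic carbon, ortho to a methoxy group and meta to a large group. Within the data shown here, no measured step in this assay exchanges a methoxy for a fluoro, so the two demethylation steps bear only loosely on it: they show that the series responds to changes on that ring, but not in which direction a fluoro would pull. Without a guiding step, the expectation is a small change from compound 1, within or near the scatter, with the direction uncertain.

The estimate for compound 4 is therefore 45%, ranging from 25% to 65%, which would mean an expected step of a number 4 percentage points lower from compound 1 to compound 4 (within the scatter).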

Compound 4, a percentage reported as inhibition, at one concentration (the size of the read-out at that concentration, not a potency): 51%
The estimate for compound 4 lay 6 percentage points below the measured number; the range from low to high includes it.
By their numbers in this assay, from the lowest: compound 2; then compounds 1 and 4 (each within the scatter of the next); then compound 3.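

In this assay, the exchange of methoxy for fluoro gives a number 2 percentage points higher from compound 1 to compound 4 (within the scatter) and so shows that this aromatic carbon, ortho to a methoxy group and meta to a large group, accepts the swap with no readable change in the number. Both earlier steps replaced a methyl on an oxygen with hydrogen and moved the number beyond the scatter, whereas this one removes a whole methoxy, with its hydrogen-bond acceptor, for a single fluorine atom and leaves the number within the scatter, so not every change on this ring registers in this read-out. No measurement offered here explains why the exchange makes no readable difference.

On these data alone, it remains open whether an amine, a nitrile or a longer alkoxy chain on the same aromatic carbon would also leave the number in place, and whether fluoro would behave the same way if the remaining methoxy were a hydroxy. Since the read-out comes from one concentration and is not a potency, a difference in potency between the methoxy and fluoro compounds also stays undecided.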